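Swapping an Acid for a Nitrile in a Leukotriene Ligand

This account rests on a few compounds, and the source may have more. Where it says the series, first, only, none or still open, it means among the compounds named here.

Among the measured compounds shown here, compound 3 `O=C(O)CCCCCCOc1cc(-c2ccccc2)cc(-c2ccccc2)n1` gives 25 nM in an assay on cell membranes from spleen (Cavia porcellus) for binding affinity to leukotriene B4 receptor 1 (Homo sapiens) (a lower number here means a stronger inhibitor, a higher number a weaker inhibitor), the highest of the three numbers measured so far: compound 1 `O=C(O)CCCCCOc1cc(-c2ccccc2)cc(-c2ccccc2)n1` gives 3 nM and compound 2 `CC(CCCCOc1cc(-c2ccccc2)cc(-c2ccccc2)n1)C(=O)O` gives 4 nM. The measured steps show an 8.3-fold higher number from compound 1 to compound 3 (0.92 log units; beyond the scatter) and a 6.3-fold higher number from compound 2 to compound 3 (0.80 log units; beyond the scatter), while a 1.3-fold higher number from compound 1 to compound 2 (0.12 log units; within the scatter). Compound 4 `N#CCCCCCOc1cc(-c2ccccc2)cc(-c2ccccc2)n1` carries cyano in place of carboxymethyl on a saturated chain carbon, five bonds along the chain from an oxygen on an aromatic ring. For the measured compounds named here, no measured step removes the acid group itself; the two steps that lie beyond the scatter only move it along the chain, yet both already cost affinity. The change to compound 4 goes further than either, so a larger step in the same direction is expected. The expected step is a 12-fold higher number from compound 3 to compound 4 (1.08 log units; beyond the scatter). Compound 4 is therefore estimated to give 300 nM, within a range from 50 nM to 3000 nM.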

Compound 4, half-maximal inhibitory concentration: 700 nM
The estimate for compound 4 lay 2.3-fold (0.37 log units) below the measured number, and the stated range covers the measured number.
By their numbers in this assay, from the lowest: compounds 1 and 2 (each within the scatter of the next); then compound 3; then compound 4.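

Replacing the acid end with a nitrile shows a 28-fold higher number from compound 3 to compound 4 (1.45 log units; beyond the scatter) and so costs far more than moving the acid along the chain did. Measured against the other two acids, the loss is wider still, with a 180-fold higher number from compound 2 to compound 4 (2.24 log units; beyond the scatter) and a 230-fold higher number from compound 1 to compound 4 (2.37 log units; beyond the scatter) on the same scale. So this chain end tolerates a shift of the acid far better than its replacement by cyano, though nothing measured here explains the loss.

Still open, on these data alone, is whether a tetrazole or a primary amide at this chain end would keep more affinity than the nitrile. As far as these compounds go, a longer chain ending in a nitrile also remains open.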